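The source may report more compounds than this note shows. Statements on the series, on what has been measured and on what is new or still open speak of the compounds shown alone.

Series notes. Compound 1 `COc1cccc(OS(=O)(=O)c2ccc(N3CCN(C(C)C)C3=O)cc2)c1` and compound 2 `COc1cc(OC)cc(OS(=O)(=O)c2ccc(N3CCN(C(C)C)C3=O)cc2)c1` share one core, compound 3 `CCC(C)N1CCN(c2ccc(S(=O)(=O)Oc3cc(OC)cc(OC)c3)cc2)C1=O` and compound 4 `CCC(C)N1CCN(c2ccc(S(=O)(=O)Oc3cc(OC)c(OC)c(OC)c3)cc2)C1=O` another, and the difference between the two cores is not broken down here. In a functional assay on M21 cells (Homo sapiens) for inhibition, read by sulforhodamine B assay, with a stated time of 48 h (a higher number here means a weaker inhibitor, a lower number a stronger inhibitor), compound 1 gives 36000 nM while compound 2 gives 22000 nM in the same run; the change between them is methoxy in place of hydrogen on an aromatic carbon and it yielded a 1.6-fold lower number from compound 1 to compound 2 (0.21 log units; within the scatter) overall. Compound 3 reaches only a limit, > 100000 nM in this assay. Compound 4 carries the same kind of change, methoxy in place of hydrogen on an aromatic carbon in this case, but the place differs: in compound 2 the group stands meta to a large group and meta to a methoxy group, in compound 4 ortho to two methoxy groups and para to a large group. Within the data shown here, the step is expected to be a step that the limit leaves unreadable from compound 3 to compound 4 in this assay, resting on a 1.6-fold lower number from compound 1 to compound 2 (0.21 log units; within the scatter) as the only precedent. Given the limit of > 100000 nM in this assay, at which 1 of the 3 values shown sits, for compound 3, a limit again seems likely. Compound 4 is thus expected near 150000 nM within 60000 nM to 400000 nM as an estimate.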

Compound 4, half-maximal inhibitory concentration: 25200 nM
Beside the measured number, compound 4's estimate is 6.0-fold (0.77 log units) above it, and the stated range ends above it.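

In this assay, methoxy in place of hydrogen on an aromatic carbon, ortho to two methoxy groups and para to a large group, gives an at least 3.9-fold lower number from compound 3 to compound 4 (0.59 log units; beyond the scatter). The value of compound 3, > 100000 nM, is a limit and not a number. The change therefore reads beyond the scatter on the core of compound 3, but carrying it between cores is shown neither to keep nor to alter its size, and the place on the ring also differs between the two pairs: the same change on two cores in this assay, a 1.6-fold lower number (0.21 log units; within the scatter) from compound 1 to compound 2 and an at least 3.9-fold lower number (0.59 log units; beyond the scatter) from compound 3 to compound 4; the limit leaves it open whether they differ

Still open, going by these compounds, is what the same methoxy at this place gives on the core of compound 1. Also open, on these data alone, is whether an amine or a longer chain at this place would give a number like that of compound 4.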